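The source may report more compounds than this note shows. Statements on the series, on what has been measured and on what is new or still open speak of the compounds shown alone.

Measured so far in a functional assay on HCT-15 cells (Homo sapiens) for antiproliferative activity, with a stated time of 48 h; on this read-out higher numbers stand for weaker inhibition and lower numbers for stronger inhibition:
- compound 1 `Cc1cc(=O)c2c(O)cc(OCC3CO3)cc2o1`: 18300 nM
- compound 2 `Cc1cc(=O)c2c(OCC3CO3)cc(OCC3CO3)cc2o1`: 12100 nM

Within the data shown here, compound 1 and compound 2 lie within the scatter of each other; the only measured step, a 1.5-fold lower number from compound 1 to compound 2 (0.18 log units; within the scatter), concerns the (oxiran-2-yl)methyl in place of hydrogen on an oxygen on an aromatic ring, not a stereo element, and so says nothing direct about the change now at hand.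

Compound 3 `Cc1cc(=O)c2c(O)cc(OC[C@H]3CO3)cc2o1` differs from compound 1 as follows: the two compounds have the same atoms and bonds; at least one stereo element is drawn with a configuration in one of them and without one in the other: 1 of 1 stereo elements differ; a stereocentre at a saturated ring carbon is drawn without a configuration in compound 1 and R in compound 3. Among the measured compounds shown here, no measured pair separates a drawn configuration from an undrawn one at this centre, so there is no step on which to build a directional expectation. Compound 3 is therefore expected to give a number within the scatter of compound 1, with a 1.0-fold lower number from compound 1 to compound 3 (0.01 log units; within the scatter) as the expected step. For compound 3 the estimate in this assay is 18000 nM, with a range from 8000 nM to 40000 nM.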

Compound 3, half-maximal inhibitory concentration: 27200 nM
Estimate against measurement, compound 3: 1.5-fold (0.18 log units) below; measured number inside the range.
By their numbers in this assay, from the lowest: compounds 2, 1 and 3 (each within the scatter of the next, the first and the last beyond it).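

In this assay, among these compounds, the first measured step at the stereocentre on the saturated ring carbon is a 1.5-fold higher number from compound 1 to compound 3 (0.17 log units; within the scatter). Drawing the R configuration at this centre thus gives no separation from the undrawn centre of compound 1, which the earlier step on the aromatic oxygen could not show. The comparison sets a defined drawing against an undefined one, not one configuration against its opposite: the fact that one of compounds 1 and 3 is drawn with a defined configuration and the other without, at the place where they differ.

On these data alone, the S configuration at this centre remains open, and so does any comparison of the two configurations with each other. Also open, as far as these compounds go, is whether an amine or a longer chain in place of the (oxiran-2-yl)methyl on this oxygen would move the number in this assay beyond the scatter.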